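The source may hold more compounds than are shown below. What is called first, only, known or untested is meant among the compounds shown, and "the series" means these compounds.

Compound 1 `CCCc1nc(-c2ccccc2)c(CNCCN2CCN(c3ccccc3Cl)CC2)o1` and compound 2 `CCCc1nc(-c2ccccc2)c(CNCCCN2CCN(c3ccc(F)cc3)CC2)o1` share one core and differ only in the aryl group on the ring amine and in the length of the linking chain. In an assay on HEK293 cells for inhibition of Voltage-dependent T-type calcium channel subunit alpha-1G (Homo sapiens), read by fluorescence, tested at 10 uM (a lower number here means less inhibition, a higher number more inhibition at the concentration tested (going by the name of the read-out)), compound 1 gives 60.1%. In this assay compound 2 gives 62.5%. These two numbers lie within the usual scatter of each other, so compound 2 cannot be set apart from compound 1 on the evidence at hand.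

Compound 3 `CCCc1nc(-c2ccccc2)c(CNCCCN2CCN(c3cccc(C(F)(F)F)c3)CC2)o1` is not yet measured. Its change from compound 2 is 3-(trifluoromethyl)phenyl in place of 4-fluorophenyl on an amine nitrogen in a ring. Among the compounds with values here, no measured pair shows the effect of such a swap, and the only comparison available, between compound 1 and compound 2, shows no difference beyond the scatter. The step of a number 2.5 percentage points lower from compound 2 to compound 3 (within the scatter) is therefore expected to stay within the scatter, with no clear direction. Compound 3 is estimated to give about 60%, most likely between 42% and 78%.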

Compound 3, a percentage reported as inhibition, at one concentration (the size of the read-out at that concentration, not a potency): 51.6%
Beside the measured number, compound 3's estimate is 8.4 percentage points above it; low and high end bracket the measured number.
By their numbers in this assay, from the lowest: compounds 3, 1 and 2 (each within the scatter of the next, the first and the last beyond it).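

Within this assay the swap to 3-(trifluoromethyl)phenyl on the ring amine nitrogen brings a number 10.9 percentage points lower from compound 2 to compound 3 (beyond the scatter) and so gives the first change in a single place that clears the scatter. The linking chain and the shared core stay the same across this pair, which ties the modest loss of inhibition to this one position and shows that the aryl group there can alter the read-out. Nothing at hand explains why the number falls.

The pair cannot separate the identity of the group on the phenyl ring from its place on that ring. Also open, on these data alone, are how a plain phenyl, a methoxyphenyl or a cyanophenyl would fare on the same nitrogen, and whether this swap would have a similar effect with the linking chain of compound 1.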